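The source may report more compounds than this note shows. Statements on the series, on what has been measured and on what is new or still open speak of the compounds shown alone.

Measured compounds:
compound 1 `Cc1ccc(S(=O)(=O)NCCCNc2nccc(-c3c(-c4cccc(F)c4)nc4sccn34)n2)cc1` — 9500 nM
compound 2 `O=C(NCCNc1nccc(-c2c(-c3cccc(F)c3)nc3sccn23)n1)c1ccc(C(F)(F)F)cc1` — 9260 nM
compound 3 `O=C(NCCNc1nccc(-c2c(-c3cccc(F)c3)nc3sccn23)n1)c1ccccc1` — 17000 nM

In a functional assay on SK-MEL-28 cells (Homo sapiens) for cytotoxicity, read by MTT assay (on this read-out lower numbers stand for stronger inhibition and higher numbers for weaker inhibition), compound 3 carries the highest of the three numbers, yet a 1.8-fold higher number from compound 1 to compound 3 (0.25 log units; within the scatter) and a 1.8-fold higher number from compound 2 to compound 3 (0.26 log units; within the scatter) both stay within the scatter, so no ordering among them is established.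

Compound 4 `O=S(=O)(NCCCNc1nccc(-c2c(-c3cccc(F)c3)nc3sccn23)n1)c1ccc(F)cc1` differs from compound 3 in one place: (((4-fluorophenyl)sulfonyl)amino)methyl in place of benzamido on a saturated chain carbon, two bonds along the chain from a nitrogen on an aromatic ring. Within the data shown here, the step that bears on it is the one from compound 1 to compound 3, which roughly retraces this change in the opposite direction and gave a 1.8-fold higher number from compound 1 to compound 3 (0.25 log units; within the scatter). Running that step backwards points to a slightly lower number for compound 4, but nothing beyond the scatter. Compound 4 is therefore expected near 9000 nM, with a range of 3500 nM to 23000 nM, a step of a 1.9-fold lower number from compound 3 to compound 4 (0.28 log units; within the scatter).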

Compound 4, half-maximal inhibitory concentration: > 20000 nM
Compound 4 gave a limit, no number; the forecaster's own chance of this, stated with the estimate: 5%; middle value at least 2.2-fold (0.34 log units) from the limit.
By their numbers in this assay, from the lowest: compounds 2, 1 and 3 (each within the scatter of the next). At a limit, above all of these: compound 4.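

In this assay compound 4 gives > 20000 nM, a limit and not a number. Fluoro in place of methyl on an aromatic carbon is the first change here with a step beyond the scatter, an at least 2.1-fold higher number from compound 1 to compound 4 (0.32 log units; beyond the scatter), while (((4-fluorophenyl)sulfonyl)amino)methyl in place of benzamido gives only an at least 1.1-fold higher number from compound 3 to compound 4 (0.07 log units; that floor lies within the scatter), so that exchange stays unresolved. How far compound 4 lies from the other compounds cannot be read: the limit of > 20000 nM in this assay, at which 1 of the 4 values shown sits.

From the compounds shown here alone, whether an amine or a carboxylic acid on that aromatic carbon would give a lower number remains open. So does the effect of a longer chain.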